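The source may hold more compounds than are shown below. What is called first, only, known or untested is meant among the compounds shown, and "the series" means these compounds.

Measured compounds in an ADME assay on LLC-MK2 cells (Macaca mulatta) for cytotoxicity, read by spectrophotometry and crystal violet staining, with a stated time of 4 days; on this read-out lower numbers stand for higher toxicity in this test and higher numbers for lower toxicity in this test:

Compound 1 `CC(C)n1ncc2c(C(=O)N3CCc4cccnc43)cc(-c3cccs3)nc21` gives 50000 nM.
Compound 2 `CC(C)n1ncc2c(C(=O)Nc3c(F)cccc3F)cc(-c3cccs3)nc21` gives > 200000 nM, which is a limit of the assay and not a number.
Compound 3 `CC(C)n1ccc2c(C(=O)Nc3ccccn3)cc(-c3cccs3)nc21` gives > 200000 nM, likewise a limit of the assay and not a number.

Compound 2 therefore stands at the top of what this assay can report: the limit of > 200000 nM in this assay, at which 2 of the 3 values shown sit, so its toxicity in this test was too weak to be pinned to a number. Within the data shown here, the only step among the measured compounds that can be sized is an at least 4.0-fold higher number from compound 1 to compound 2 (0.60 log units; beyond the scatter), and it concerns an exchange of a different group on a carbonyl carbon, ending at that same limit.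

Compound 4 `CC(C)n1ncc2c(C(=O)Nc3cccc(C(N)=O)c3)cc(-c3cccs3)nc21` has not yet been measured. It differs from compound 2 by 3-carbamoylphenyl in place of 2,6-difluorophenyl on an amide-type nitrogen. Among the measured compounds shown here, no measured pair swaps one group for another on the amide-type nitrogen, so no step bears directly on this change; the only guide is that most of the values shown sit at the limit. I therefore expect no step beyond the scatter, and compound 4 is expected to stay close to that limit, with a number no higher from compound 2 to compound 4 (the limit leaves the size open). My estimate for compound 4 is 200000 nM, in a range from 80000 nM to 400000 nM, and it will most probably again be reported only as a limit.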

Compound 4, half-maximal cytotoxic concentration: 25000 nM
Compound 4: the middle estimate sits 8.0-fold (0.90 log units) above what was measured, and the stated range ends above it.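

In this assay, the group on the amide-type nitrogen proves able to change the read-out on its own: 3-carbamoylphenyl in place of 2,6-difluorophenyl gives an at least 8.0-fold lower number from compound 2 to compound 4 (0.90 log units; beyond the scatter). Among these compounds, until now, the only step that could be sized was an exchange on the carbonyl carbon, so this is the first sign that the amide-type nitrogen is also a place where toxicity in this test can appear while the rest of the molecule stays the same. As far as these compounds go, the true size of the step remains unknown because compound 2 is reported only as a limit and not as a number: the limit of > 200000 nM in this assay, at which 2 of the 4 values shown sit.

This single exchange removes the two fluorines and adds a carbamoyl group with its hydrogen-bond donor and acceptor, and the compounds shown cannot tell which of these changes matters, or whether both do. An unsubstituted phenyl group on this nitrogen would separate the two changes, while a 3-carboxyphenyl or 3-aminophenyl group would test whether the lower number depends on the carbamoyl group itself.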